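From cyclopentyl to 1-ethoxyethyl on a shared core

The compounds below may be only part of what the source reports. "The series", "measured", "known", "first", "only" and "open" are said of these compounds alone.

Compound 1 `Cc1cc(C)c(NC(=O)Nc2cnc(-n3nccn3)c(Cl)c2)cn1`: > 20000 nM
Compound 2 `O=C(Nc1cnc(-n2nccn2)c(Cl)c1)Nc1cnc2ccccc2c1C1CCCC1`: 7020 nM

Of the compounds shown here, two have been tested in a functional assay on OCI-Ly3 cells (Homo sapiens) for antiproliferative activity; a lower number here means that less compound is needed, a higher number that more compound is needed for the effect. Compound 1 gives > 20000 nM, which is a limit of the assay and not a number. Among the measured compounds shown here, compound 2 gives 7020 nM, the only actual number available, so it stands as the sole reference point. Compound 3 `CCOC(C)c1c(NC(=O)Nc2cnc(-n3nccn3)c(Cl)c2)cnc2ccccc12` keeps the core of compound 2 and changes one group: 1-ethoxyethyl in place of cyclopentyl on an aromatic carbon. Here, 1-ethoxyethyl stands in place of cyclopentyl on an aromatic carbon, opposite the ring nitrogen. For the measured compounds named here, no measured pair tests this exchange, so the expectation is loose: a moderate step toward less compound needed in this assay, although a step within the scatter remains possible. The estimated change is a 2.3-fold lower number from compound 2 to compound 3 (0.37 log units; beyond the scatter). For compound 3 the expected value is 3000 nM, with an estimated range from 500 nM to 15000 nM.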

Compound 3, half-maximal effective concentration: 1530 nM
Estimate against measurement, compound 3: 2.0-fold (0.29 log units) above, and the stated range covers the measured number.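

In this assay, among the compounds shown here, 1-ethoxyethyl in place of cyclopentyl gives a 4.6-fold lower number from compound 2 to compound 3 (0.66 log units; beyond the scatter), the only measured step at this aromatic carbon, opposite the ring nitrogen. It shows that this position accepts a group with no ring and one hydrogen-bond acceptor, and that the number falls with this exchange rather than rises. Compound 1 stands at a limit of the assay, not a number, and enters no comparison: the limit of > 20000 nM in this assay, at which 1 of the 3 values shown sits.

This single exchange removes the ring and brings in the oxygen together, so the compounds shown do not tell which of the two changes carries the step. A tetrahydrofuranyl ring or an open alkyl chain on the same carbon would separate the two, and an amine there would test whether the oxygen can be replaced.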